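This account rests on a few compounds, and the source may have more. Where it says the series, first, only, none or still open, it means among the compounds named here.

In a physicochemical assay for solubility, with a stated time of 24 h, tested at 30 mg/mL (a lower number here means a less soluble compound, a higher number a more soluble compound), compound 2 `Cc1cc(COc2ccc(S(=O)(=O)NC3(C(=O)NO)CN(C(=O)C(C)C)C3)cc2)c2ccccc2n1` gives 17000000 nM, the second highest of three numbers. Compound 3 `CCN(C1(C(=O)NO)CN(C(=O)C(C)C)C1)S(=O)(=O)c1ccc(OCc2cc(C)nc3ccccc23)cc1` gives 44000000 nM, and compound 1 `Cc1cc(COc2ccc(S(=O)(=O)NC3(CC(=O)NO)CN(C(=O)CC(C)C)C3)cc2)c2ccccc2n1` gives 900000 nM. Compound 4 `Cc1cc(COc2ccc(S(=O)(=O)NC3(C(=O)NO)CN(C(=O)CC(C)C)C3)cc2)c2ccccc2n1` is unmeasured and departs from compound 2 at one place: isobutyl in place of isopropyl on a carbonyl carbon. Among the measured compounds shown here, the only measured single-place step, a 2.6-fold higher number from compound 2 to compound 3 (0.41 log units; beyond the scatter), lies on a sulfonamide nitrogen, so it indicates only a typical step size, not this change. Compound 1 also carries isobutyl on that carbonyl but differs elsewhere, and it gives the lowest number, 900000 nM, so a modest move to a lower number is expected. The expected step is a 2.1-fold lower number from compound 2 to compound 4 (0.33 log units; beyond the scatter). For compound 4 the estimated value is 8000000 nM, within an expected range of 2000000 nM to 25000000 nM.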

Compound 4, solubility: 5000000 nM
The estimate for compound 4 lay 1.6-fold (0.20 log units) above the measured number; measured number inside the range.
By their numbers in this assay, from the lowest: compound 1; then compound 4; then compound 2; then compound 3.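

Among the compounds shown here, on a carbonyl carbon with an amide-type nitrogen in a ring as its other neighbour, isobutyl in place of isopropyl gives, in this assay, a 3.4-fold lower number from compound 2 to compound 4 (0.53 log units; beyond the scatter), the first single-place reading at this position. Hydroxycarbamoyl in place of (hydroxycarbamoyl)methyl on a saturated ring carbon gives a 5.6-fold higher number from compound 1 to compound 4 (0.74 log units; beyond the scatter), so this second position also moves the number beyond the scatter. No measurement bearing on either step is available.

Going by these compounds, whether a longer chain or an amine on that carbonyl carbon would give a still lower number remains open. Also open, on these data alone, is whether the isobutyl step holds with ethyl on the sulfonamide nitrogen.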